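Fluorine enters the aryl ring of compound 1

The source may report more compounds than this note shows. Statements on the series, on what has been measured and on what is new or still open speak of the compounds shown alone.

Compound 1 `O=C(Nc1ccc(C(F)(F)F)cc1)NC1CCN(C(=O)C2CCCOC2)CC1` carries an oxan-3-yl group on its carbonyl carbon. In a physicochemical assay for lipophilicity, read by HPLC, with a stated time of 90 min, tested at 100 uM (on this read-out higher numbers stand for higher lipophilicity and lower numbers for lower lipophilicity), compound 1 gives 3.41. Within the data shown here, its two measured relatives change only that group: compound 2 `O=C(Nc1ccc(C(F)(F)F)cc1)NC1CCN(C(=O)c2ccoc2)CC1` gives 3.5 in this assay, and compound 3 `O=C(Nc1ccc(C(F)(F)F)cc1)NC1CCN(C(=O)c2cc[nH]c2)CC1` gives 3.26. Among these three numbers compound 1 stands second highest, yet every step is small: a number 0.09 log units higher from compound 1 to compound 2 (within the scatter), a number 0.15 log units lower from compound 1 to compound 3 (within the scatter) and a number 0.24 log units lower from compound 2 to compound 3 (within the scatter) all lie within the scatter, so no order among the three can be read from them.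

Compound 4 `O=C(Nc1ccc(C(F)(F)F)c(F)c1)NC1CCN(C(=O)C2CCCOC2)CC1` differs from compound 1 in one place: fluoro in place of hydrogen on an aromatic carbon. The fluorine enters on an aromatic carbon of a six-membered aromatic ring of carbon only, ortho to a trifluoromethyl group and meta to a large group. None of the three measured steps touches that ring; all of them exchange the group on the carbonyl carbon, and none moved the read-out beyond the scatter. Among the measured compounds shown here, for the change on the aromatic ring there is thus no measured precedent in this set, and the value of compound 1, 3.41, is the only anchor.

Compound 4 is therefore expected to give 3.55 in this assay, within a range of 3.3 to 3.8. The step this estimate implies, a number 0.14 log units higher from compound 1 to compound 4 (within the scatter), is expected to stay within the scatter.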

Compound 4, partition coefficient: 3.84
Beside the measured number, compound 4's estimate is 0.29 log units below it, outside the stated range (above it).
By their numbers in this assay, from the lowest: compounds 3, 1 and 2 (each within the scatter of the next); then compound 4.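

In this assay, among these compounds, fluoro in place of hydrogen on an aromatic carbon, ortho to a trifluoromethyl group and meta to a large group, gives a number 0.43 log units higher from compound 1 to compound 4 (beyond the scatter) and so provides the first step in the set that passes beyond the scatter. The three exchanges on the carbonyl carbon all stayed within the scatter, so this aromatic position, changed by 1 heavy atom, moved the read-out where swapping the whole group on the carbonyl carbon did not, although the step is modest and rests on a single pair. Nothing among the data shown accounts for the rise at this position.

The compounds shown leave open whether the same fluoro would give a step of like size with the furan-3-yl of compound 2 or the 1H-pyrrol-3-yl of compound 3 on the carbonyl carbon. They also leave open what a chloro, a methoxy or an amine on this same aromatic carbon would do to the read-out, and whether fluoro on another carbon of that ring would behave alike.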